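Head Group Swap in a Sodium Channel Sulfonamide Series

The source may report more compounds than this note shows. Statements on the series, on what has been measured and on what is new or still open speak of the compounds shown alone.

Three measured compounds set the scene. In an assay on cells for inhibition of sodium channel protein type 3 subunit alpha (Homo sapiens), read by electrophysiology (on this read-out lower numbers stand for stronger inhibition and higher numbers for weaker inhibition), compound 1 `O=S(=O)(Nc1nccs1)c1ccc(-c2nnc(Cc3ccc(C(F)(F)F)cc3)[nH]2)cc1` gives 124 nM. Compound 2 `O=C(NCc1ccccc1)c1ccc(S(=O)(=O)Nc2nccs2)cc1` gives 4450 nM in this assay, and compound 3 `O=C(NCc1ccc(OC(F)(F)F)c(Cl)c1)c1ccc(S(=O)(=O)Nc2ncc(F)cn2)c(F)c1` gives 993 nM. Compound 3 therefore holds the second highest of the three numbers: its nearest neighbour is compound 2, with a higher number, and its furthest is compound 1, with a lower number, and both gaps lie beyond the scatter. Compounds 2 and 3 share a core but differ in several places at once, so their pair says nothing about any single change.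

The compound still to be measured, compound 4 `O=C(NCc1ccc(OC(F)(F)F)c(Cl)c1)c1ccc(S(=O)(=O)Nc2cncnc2)c(F)c1`, differs from compound 3 in one place only: pyrimidin-5-yl in place of 5-fluoropyrimidin-2-yl on a sulfonamide nitrogen. Within the data shown here, no measured pair shows this change, so its size cannot be read from the data and has to be estimated.

The step of a 3.0-fold higher number from compound 3 to compound 4 (0.48 log units; beyond the scatter) is expected to lie beyond the scatter, in the direction of weaker inhibition, since the ring attaches through a different carbon and loses its fluorine. Compound 4 is estimated at 3000 nM, with a range from 900 nM to 10000 nM.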

Compound 4, half-maximal inhibitory concentration in the sodium channel protein type 3 subunit alpha assay: > 3000 nM
Compound 4: a limit, no number (the forecaster's own chance of this, stated with the estimate: 15%); the middle value sits exactly at the limit.
By their numbers in the sodium channel protein type 3 subunit alpha assay, from the lowest: compound 1; then compound 3; then compound 2.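

Among these compounds, this is the first comparison that differs in one place only, and it shows that the sulfonamide nitrogen is sensitive to which ring it carries: in the sodium channel protein type 3 subunit alpha assay, with pyrimidin-5-yl in place of 5-fluoropyrimidin-2-yl, compound 4 gives > 3000 nM, a limit of the assay and not a number, and the change gives an at least 3.0-fold higher number from compound 3 to compound 4 (0.48 log units; beyond the scatter). The step therefore has a smallest size but no known full size: the limit of > 3000 nM in the sodium channel protein type 3 subunit alpha assay, at which 1 of the 4 values shown sits. In a physicochemical assay for lipophilicity (on this read-out lower numbers stand for lower lipophilicity and higher numbers for higher lipophilicity), compound 3 gives 2.1 and compound 4 gives 2. The same change there gives a number 0.10 log units lower from compound 3 to compound 4 (within the scatter), so the two compounds cannot be told apart on lipophilicity, although they do separate on inhibition.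

The change moves the point of attachment and removes the fluorine in a single step, so the compounds shown cannot say which of the two accounts for the weaker inhibition, and a ring carrying only one of these changes would be needed to separate them. From the compounds shown here alone, how other groups on the sulfonamide nitrogen, such as a pyridine ring or a simple methyl group, would read in the sodium channel protein type 3 subunit alpha assay also stays open.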